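Trimming the benzyloxy tail while watching cytotoxicity

The compounds below may be only part of what the source reports. "The series", "measured", "known", "first", "only" and "open" are said of these compounds alone.

Compound 1 `CCOC(=O)CCCCCOc1cccc(CN(C(=O)c2ccccc2)C(C)C)c1` and compound 2 `CCOC(=O)CCCCCOc1cccc(CN(C(=O)c2ccc(-c3cccc(OCc4ccccc4)c3)cc2)C(C)C)c1` share a core that differs only in what hangs on the benzamide end. In an ADME assay on BJ cells (Homo sapiens) for cytotoxicity, read by CellTiter-Glo and resazurin assay, with a stated time of 72 h (a higher number here means that more compound is needed for the effect, a lower number that less compound is needed), compound 1 gives > 26000 nM, which is a limit of the assay rather than a number. In this assay compound 2 likewise gives > 26000 nM, again a limit and not a number. Compound 2 therefore stands at the limit of > 26000 nM in this assay, at which 2 of the 2 values shown sit, with no measured value that would set it apart from compound 1.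

Compound 3 `CCOC(=O)CCCCCOc1cccc(CN(C(=O)c2ccc(-c3cccc(OC)c3)cc2)C(C)C)c1` is the next member. The change from compound 2 to compound 3 is hydrogen in place of phenyl on a saturated chain carbon bound to an oxygen on an aromatic ring; cut one bond further out, benzyloxy becomes methoxy. Within the data shown here, no step between measured compounds is available to size this change. Since both compound 1 and compound 2 sit at the limit, the expected step that the limit leaves unreadable from compound 2 to compound 3 is none beyond the scatter. For compound 3 in this assay the estimate is 30000 nM, within 10000 nM to 100000 nM, most probably reported again only as a limit.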

Compound 3, half-maximal effective concentration: > 21000 nM
Compound 3 was reported as a limit (the forecaster's own chance of this, stated with the estimate: 80%); the middle value lies beyond the limit too.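

In this assay compound 3 gives > 21000 nM, which is a limit and not a number. Compound 1 and compound 2 are also reported only as limits, so neither step to compound 3 can be read. The compounds shown leave open at what concentration any of the three affects these cells, and whether benzyloxy and methoxy differ at all.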